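Cytotoxicity notes: the acetyl side chain of compound 3

The compounds below may be only part of what the source reports. "The series", "measured", "known", "first", "only" and "open" are said of these compounds alone.

Measured compounds:
compound 1 `CCC(=O)N1N=C(c2cc3ccccc3oc2=O)CC1c1ccccc1`: 9610 nM
compound 2 `Cc1ccc(S(=O)(=O)N2N=C(c3cc4ccccc4oc3=O)CC2c2ccccc2)cc1`: "not active" (no number reported)
compound 3 `CC(C)CNCC(=O)N1N=C(c2cc3ccccc3oc2=O)CC1c1ccccc1`: 9970 nM

For the measured compounds named here, in a functional assay on HepG2 cells (Homo sapiens) for cytotoxicity, read by MTT assay, with a stated time of 48 h (a lower number here means a stronger inhibitor, a higher number a weaker inhibitor), only two numbers exist for this set. Compound 3 and compound 1 are indistinguishable within the scatter, and compound 2, which carries a sulfonyl group on the ring nitrogen instead of an acyl group, returned no number at all. Going by the values given here, the one step that touches the side chain in question, a 1.0-fold higher number from compound 1 to compound 3 (0.02 log units; within the scatter), shows that attaching isobutylamino to the saturated chain carbon bound to the carbonyl carbon left the read-out unchanged.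

Compound 4 `NC(=O)C1CCN(CC(=O)N2N=C(c3cc4ccccc4oc3=O)CC2c2ccccc2)CC1` differs from compound 3 in exactly that place: 4-carbamoylpiperidin-1-yl in place of isobutylamino on a saturated chain carbon bound to a carbonyl carbon. Among the compounds with values here, the only measured step bearing on this position is the one from compound 1 to compound 3, and it was within the scatter. The data give no hint that a different amine on this chain carbon moves the read-out, so no step beyond the scatter is expected in this assay, a 1.0-fold higher number from compound 3 to compound 4 (0.00 log units; within the scatter). Compound 4 is therefore estimated at 10000 nM, with a plausible range from 4000 nM to 25000 nM. The result of compound 2 is a reminder that a no-number outcome also remains possible.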

Compound 4, half-maximal inhibitory concentration: 19300 nM
Compound 4: middle estimate off by 1.9-fold (0.29 log units), on the low side; low and high end bracket the measured number.
By their numbers in this assay, from the lowest: compounds 1, 3 and 4 (each within the scatter of the next).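

Working notes, side chain: in this assay, 4-carbamoylpiperidin-1-yl in place of isobutylamino gives a 1.9-fold higher number from compound 3 to compound 4 (0.29 log units; within the scatter) and so extends the tolerated groups on the saturated chain carbon bound to a carbonyl carbon. The earlier compounds shown here covered only methyl and the open-chain isobutylamino, whereas this group brings a six-membered non-aromatic ring and a higher heavy-atom count to the same place. Set against methyl directly, the same group gives a 2.0-fold higher number from compound 1 to compound 4 (0.30 log units; within the scatter) as a second step, so methyl, isobutylamino and 4-carbamoylpiperidin-1-yl cannot be told apart in this assay at this position, and no change of group here has yet produced a step beyond the scatter. Nothing at hand offers an explanation for these numbers.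

Still open, on these data alone, is whether a piperidine bearing a carboxylic acid in place of the carbamoyl group, or a morpholine or an aniline on the same chain carbon, would separate from these three compounds in this assay. A longer chain between the carbonyl and the amine is equally untested in the compounds shown, so the dependence of the read-out on that distance remains unknown.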